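A fluorine added to the benzyl ring of compound 3

A few compounds are considered here, and "the series" means these few. Any claim that something is new, unique, unknown or untested is made for them only; others in the source may bear on it.

Compound 1, `N#C/N=C(\NCCCc1ccccc1)NCCCc1c[nH]cn1`, gives 5.25 in an in vitro functional assay on Sf9 cells for antagonist activity at histamine H2 receptor (Homo sapiens); on this read-out higher numbers stand for higher potency (the scale is a negative logarithm) and lower numbers for lower potency. Compound 2, `N#C/N=C(/NCCCc1c[nH]cn1)NCCSc1ccccc1`, reaches only the assay limit < 5. Compound 3, `N#C/N=C(/NCCCCc1c[nH]cn1)NCCCc1ccccc1`, gives 5.25.

Compound 3 stands level with compound 1, as the step of no change at the digits printed from compound 1 to compound 3 (within the scatter) shows. Compound 4, `N#C/N=C(/NCCCCc1c[nH]cn1)NCCCc1ccc(F)cc1`, differs from compound 3 by fluoro in place of hydrogen on an aromatic carbon. Among the measured compounds shown here, no measured step changes a substituent on the six-membered ring; the one step that touches that end of the chain, a number at least 0.25 log units lower from compound 1 to compound 2 (that floor lies within the scatter), replaces the whole benzyl group and ends at the limit (the limit of < 5 in this assay, at which 1 of the 3 values shown sits), so it gives little guidance for a single fluoro. For compound 4 the step of no change at the digits printed from compound 3 to compound 4 (within the scatter) is therefore expected to lie within the scatter. Compound 4 is estimated at 5.25, within 4.8 to 5.7.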

Compound 4, negative logarithm of the antagonist equilibrium constant: 5.28
For compound 4 the middle estimate is 0.03 log units below the measured one; low and high end bracket the measured number.
By their numbers in this assay, from the lowest: compounds 1, 3 and 4 (each within the scatter of the next). At a limit, below all of these: compound 2.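

In this assay, 4-fluorobenzyl in place of benzyl gives a number 0.03 log units higher from compound 3 to compound 4 (within the scatter). Among the compounds shown here, the earlier steps changed the chain or replaced the whole benzyl group, so this is the only reading of a substituent on the six-membered ring, and at this position fluoro shows no change beyond the scatter. Nothing given here offers a reason for the size of this step.

On these data alone, whether chloro, methoxy, trifluoromethyl or an amine at this position would behave the same stays open. So does whether fluoro would do so on the shorter chain of compound 1.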